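Pyridin-4-yl in place of (oxolan-2-yl)methyl on the ring nitrogen

This account rests on a few compounds, and the source may have more. Where it says the series, first, only, none or still open, it means among the compounds named here.

Three compounds share one core. Compound 1 `Cc1cccc2sc(NC(=O)CCN3CCN(CCN(C)C)CC3)nc12` gives 1000 nM in an assay on membranes from brain for displacement of a labelled ligand from Sigma non-opioid intracellular receptor 1 (Cavia porcellus), read by scintillation counting, with a stated time of 120 min; on this read-out lower numbers stand for stronger inhibition and higher numbers for weaker inhibition; compound 2 `Cc1cccc2sc(NC(=O)CCN3CCN(CCCN(C)C)CC3)nc12` gives 570 nM; compound 3 `Cc1cccc2sc(NC(=O)CCN3CCN(CC4CCCO4)CC3)nc12` gives 109 nM, the lowest of the three. The steps of a 9.2-fold lower number from compound 1 to compound 3 (0.96 log units; beyond the scatter) and a 5.2-fold lower number from compound 2 to compound 3 (0.72 log units; beyond the scatter) show that exchanging a dimethylamino-bearing chain for oxolan-2-yl on the ring nitrogen brought modest improvement. Compound 4 `Cc1cccc2sc(NC(=O)CCN3CCN(c4ccncc4)CC3)nc12` carries pyridin-4-yl in place of (oxolan-2-yl)methyl on an amine nitrogen in a ring. Going by the values given here, no measured step tests an aromatic ring at this place, so the expectation rests only on this position having tolerated varied groups within a modest span. The step of a 1.8-fold higher number from compound 3 to compound 4 (0.26 log units; within the scatter) is therefore expected to be small, with no clear direction. The estimate for compound 4 is 200 nM, between 50 nM and 800 nM.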

Compound 4, inhibition constant: 9600 nM
The estimate for compound 4 lay 48-fold (1.68 log units) below the measured number; measured number outside the range, above it.
By their numbers in this assay, from the lowest: compound 3; then compounds 2 and 1 (each within the scatter of the next); then compound 4.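

In this assay, going by these compounds alone, this position proves far less tolerant than the earlier compounds suggested, with an 88-fold higher number from compound 3 to compound 4 (1.94 log units; beyond the scatter) as the largest step. The same loss appears against both dimethylamino-bearing chains, with a 17-fold higher number from compound 2 to compound 4 (1.23 log units; beyond the scatter) and a 9.6-fold higher number from compound 1 to compound 4 (0.98 log units; beyond the scatter), so pyridin-4-yl on the ring nitrogen falls behind all three earlier groups. Nothing measured here gives a reason for this loss. On these data alone, what remains open is whether any aromatic ring on this nitrogen has the same result, as phenyl might show. Pyridin-4-ylmethyl or benzyl could show whether a single carbon link to the nitrogen changes it.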